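The compounds below may be only part of what the source reports. "The series", "measured", "known", "first", "only" and "open" are said of these compounds alone.

The set rests on a shared core that appears in compound 1 `C=CCn1c(=O)/c(=C\c2ccc(Cl)c(Cl)c2)[nH]c(=O)/c1=C\c1ccccc1`, compound 2 `COc1ccccc1/C=c1\c(=O)[nH]/c(=C/c2ccccc2Cl)c(=O)n1C` and compound 3 `C=CCn1c(=O)/c(=C\c2ccc(F)c(Br)c2)[nH]c(=O)/c1=C\c1ccccc1OC`, and the three are read in a functional assay on Huh-7 cells (Homo sapiens) for cytotoxicity, read by CCK-8 assay, with a stated time of 72 h; on this read-out higher numbers stand for weaker inhibition and lower numbers for stronger inhibition. In this assay, within the data shown here, compound 2 gives 300 nM, the only number the set holds. Compound 1 gives "not active" (no number reported) in this assay, so no number is attached to it. Compound 3 likewise gives "not active" (no number reported) in this assay. Compound 3 therefore stands without a single number, and it is not alone: one further entry in the set also has no single number, so the whole comparison rests on what compound 2 shows and on two entries that report nothing measurable.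

Compound 4 `C=CCn1c(=O)/c(=C\c2ccc(C)cc2)[nH]c(=O)/c1=C\c1ccccc1OC` differs from compound 3 in one place: 4-methylphenyl in place of 3-bromo-4-fluorophenyl on a double-bonded chain carbon bound to an aromatic carbon. Among the measured compounds shown here, no step between measured compounds exists that could calibrate this change, and compound 3 itself offers no number from which a step could start. Given that compound 3 gives "not active" (no number reported) and compound 1 gives "not active" (no number reported) in this assay, the expectation is that compound 4 will again fall outside the measurable range rather than move by a step beyond the scatter in either direction. Should a number come back, compound 4 is expected near 20000 nM in this assay, within 3000 nM to 100000 nM.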

Compound 4, half-maximal inhibitory concentration: "not active" (no number reported)
Nothing numeric was reported for compound 4, and the estimate cannot be compared.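

In this assay compound 3 gives "not active" (no number reported) and compound 4 gives "not active" (no number reported), so no step can be read between compound 3 and compound 4. The compounds shown leave open whether 4-methylphenyl in place of 3-bromo-4-fluorophenyl can shift this read-out at all. No evidence bears on this result.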